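Chain length at the limit: from compound 3 to compound 4

The source may hold more compounds than are shown below. What is called first, only, known or untested is meant among the compounds shown, and "the series" means these compounds.

- Compound 1 `Nc1nc2cc(-c3nn(CCCCCCCCCC(=O)NO)c4ncnc(N)c34)ccc2o1`: > 50000 nM (a limit)
- Compound 2 `Nc1ncnc2c1c(-c1cnc3[nH]ccc3c1)nn2CCCCCCCCCC(=O)NO`: 10100 nM
- Compound 3 `Nc1nc2cc(-c3nn(CCC(=O)NO)c4ncnc(N)c34)ccc2o1`: > 50000 nM (a limit)

In a functional assay on MDA-MB-231 cells (Homo sapiens) for inhibition, read by MTT assay, with a stated time of 72 h (on this read-out lower numbers stand for stronger inhibition and higher numbers for weaker inhibition), compound 3 gives > 50000 nM, which is a limit and not a number. It is not alone there: the limit of > 50000 nM in this assay, at which 2 of the 3 values shown sit.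

Compound 4 `Nc1nc2cc(-c3nn(CCCCCC(=O)NO)c4ncnc(N)c34)ccc2o1` keeps the core of compound 3 and lengthens the chain: 3-(hydroxycarbamoyl)propyl in place of hydroxycarbamoyl on a saturated chain carbon, two bonds along the chain from an aromatic nitrogen. Its new 3-(hydroxycarbamoyl)propyl group is still shorter than the 7-(hydroxycarbamoyl)heptyl of compound 1.

The closest measured chain change is a step that the two limits leave unreadable from compound 1 to compound 3, so it gives no size to carry over. The other measured change is an at least 4.9-fold lower number from compound 1 to compound 2 (0.69 log units; beyond the scatter), but it alters the aromatic group, which compound 4 leaves as it is in compound 1. A reading near the limit is therefore expected, perhaps with a modest move towards lower numbers. The expected change is an at least 1.4-fold lower number from compound 3 to compound 4 (0.15 log units; that floor lies within the scatter). Compound 4 is estimated at 35000 nM, with an expected range of 9000 nM to 70000 nM.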

Compound 4, half-maximal inhibitory concentration: 19000 nM
For compound 4 the middle estimate is 1.8-fold (0.27 log units) above the measured one, within the range that was stated.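

Lengthening the chain on the shared core brings the first real number for this core in this assay, with an at least 2.6-fold lower number from compound 3 to compound 4 (0.42 log units; beyond the scatter). Lengthening it further does not carry on the gain: coming down from the 7-(hydroxycarbamoyl)heptyl chain gives an at least 2.6-fold lower number from compound 1 to compound 4 (0.42 log units; beyond the scatter), so among these three compounds the middle chain reads lower than both the shortest and the longest. On these data alone, compound 1 and compound 3 each stand at a limit and not at a number, so both steps give only a floor, and the true gaps remain unknown: the limit of > 50000 nM in this assay, at which 2 of the 4 values shown sit.

The compounds shown leave open whether a chain a little shorter or longer than that of compound 4 would read lower still. They also leave open whether a carboxylic acid in place of the hydroxycarbamoyl end would keep the reading, and how the aromatic group of compound 2 behaves on this shorter chain.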